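Shortening the Side Chain of a Furanyl Diterpenoid

The source may report more compounds than this note shows. Statements on the series, on what has been measured and on what is new or still open speak of the compounds shown alone.

Measured compounds:
- compound 1, `C=C(C)CCC[C@]1(C)C2=CCC[C@](C)(C[C@@H](O)c3ccoc3)[C@H]2CC[C@H]1C`, gives 63100 nM in a functional assay on HT-29 cells (Homo sapiens) for antiproliferative activity, read by XTT assay, with a stated time of 72 h; on this read-out lower numbers stand for stronger inhibition and higher numbers for weaker inhibition
- compound 2, `C=C(C)CCC[C@]1(C)C2=CCC[C@](C)(CC(=O)c3ccoc3)[C@H]2CC[C@H]1C`, reaches only a limit of this assay, > 100000 nM

Among the compounds with values here, compound 1 thus holds the only true number; the other value is a limit. Within the data shown here, the single measured step, an at least 1.5-fold higher number from compound 1 to compound 2 (0.19 log units; that floor lies within the scatter), is bounded by the limit of > 100000 nM in this assay, at which 1 of the 2 values shown sits, and so cannot be sized beyond its floor.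

Compound 3, `C=C(C)CC[C@]1(C)C2=CCC[C@](C)(C[C@@H](O)c3ccoc3)[C@H]2CC[C@H]1C`, differs from compound 1 by 1-methylethenyl in place of 2-methylprop-2-en-1-yl on a saturated chain carbon, two bonds along the chain from a saturated ring carbon. Among the measured compounds shown here, the measured step concerns the (furan-3-yl)(hydroxy)methyl group, not this chain, so no measured step bears on the change. With the hydroxy-bearing group kept as in compound 1, compound 3 is expected to give a number close to that of compound 1, a step of a 1.0-fold lower number from compound 1 to compound 3 (0.00 log units; within the scatter), within the usual scatter. Compound 3 is therefore estimated at 63000 nM, between 25000 nM and 160000 nM in this assay.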

Compound 3, half-maximal inhibitory concentration: 30000 nM
For compound 3 the middle estimate is 2.1-fold (0.32 log units) above the measured one, within the range that was stated.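

Within the data shown here, until this point, the only measured change concerned the (furan-3-yl)(hydroxy)methyl group, and its limit meant that step could not be sized. Among these compounds, compound 3 gives the first sized step on the side chain: in this assay, 1-methylethenyl in place of 2-methylprop-2-en-1-yl gives a 2.1-fold lower number from compound 1 to compound 3 (0.32 log units; beyond the scatter), so a change at this chain position does move the read-out, and here the shorter chain goes with stronger inhibition, though only modestly. Nothing shown here explains this shift.

The compounds shown leave open whether a still shorter chain, a longer chain, or a chain ending in an amine or a carboxylic acid would move the number further. They also leave open how the (furan-3-yl)carbonyl group of compound 2 would behave on the shorter chain of compound 3.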